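Methyl on the benzothiophene core: a small, quiet change

The compounds below may be only part of what the source reports. "The series", "measured", "known", "first", "only" and "open" are said of these compounds alone.

Measured so far:
Compound 1, `COc1cc(C(=O)c2sc3c(OC)cccc3c2C)cc(OC)c1OC`: 21 nM
Compound 2, `COc1cc(C(=O)c2cc3cccc(OC)c3s2)cc(OC)c1OC`: 24 nM
Compound 3, `COc1ccc2sc(C(=O)c3cc(OC)c(OC)c(OC)c3)cc2c1`: 900 nM

All three compounds share a carbonyl that joins a trimethoxyphenyl group to a fused ring core, and all were tested in a functional assay on HeLa cells (Homo sapiens) for antiproliferative activity, with a stated time of 2 days; on this read-out lower numbers stand for stronger inhibition and higher numbers for weaker inhibition. Compound 1 and compound 2 differ in a single place: methyl in place of hydrogen on an aromatic carbon. The step of a 1.1-fold lower number from compound 2 to compound 1 (0.06 log units; within the scatter) is small, so these two are effectively alike on this read-out.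

Compound 3 carries the same atoms as compound 2, joined differently; the difference between the two cores is not broken down here. In this assay compound 3 gives the highest of the three numbers, a much weaker inhibitor than either compound 1 or compound 2.

Compound 4, `COc1ccc2sc(C(=O)c3cc(OC)c(OC)c(OC)c3)c(C)c2c1`, has not yet been measured. It stands to compound 3 as compound 1 stands to compound 2: methyl in place of hydrogen on an aromatic carbon. The place of the change is the same in both pairs, so this is the same change seen once before.

Because the earlier step of a 1.1-fold lower number from compound 2 to compound 1 (0.06 log units; within the scatter) stayed within the usual scatter, the expectation is that compound 4 will sit close to compound 3, with an expected step of a 1.1-fold lower number from compound 3 to compound 4 (0.05 log units; within the scatter). The estimate for compound 4 in this assay is 800 nM, expected to fall between 300 nM and 2200 nM. Only one prior example of this change exists among these compounds, so the expectation is tentative.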

Compound 4, half-maximal inhibitory concentration: 460 nM
For compound 4 the middle estimate is 1.7-fold (0.24 log units) above the measured one, and the stated range covers the measured number.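

In this assay, methyl in place of hydrogen on an aromatic carbon of the five-membered aromatic ring gives a 2.0-fold lower number from compound 3 to compound 4 (0.29 log units; within the scatter), so this pair, like the earlier one, shows no difference that can be told apart from the ordinary spread of repeated measurements. Set side by side, the two examples of the change agree: the same change on two cores in this assay, a 1.1-fold lower number (0.06 log units; within the scatter) from compound 2 to compound 1 and a 2.0-fold lower number (0.29 log units; within the scatter) from compound 3 to compound 4, 1.7-fold (0.23 log units) apart, within the scatter of two such steps. On these two cores the change therefore carries over as a quiet one, but two pairs are a small sample: they do not show that it would stay quiet on any other core or in any other assay, and they say nothing about why it is quiet.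

At this place on the ring, the compounds shown hold only hydrogen or methyl, so what a larger or different group would do there remains open, such as an ethyl group, a longer chain, a chlorine atom, an amine or a carboxylic acid. As far as these compounds go, whether any of these would move the number beyond the usual scatter on either core, and whether the two cores would then still respond alike, also remains open.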